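This account rests on a few compounds, and the source may have more. Where it says the series, first, only, none or still open, it means among the compounds named here.

Compound 1 `CC1=C(C(N)=O)C(c2ccoc2)NC(=O)N1`: 6%
Compound 2 `CC1=C(C(N)=O)C(c2ccsc2)NC(=O)N1`: 1%

In an assay on membranes from HEK293 cells for displacement of a labelled ligand from adenosine receptor A2b (Homo sapiens), read by scintillation counting, with a stated time of 30 min, tested at 1 uM (on this read-out lower numbers stand for less inhibition and higher numbers for more inhibition at the one concentration tested (going by the name of the read-out)), compound 1 and compound 2 give numbers that the step of a number 5 percentage points lower from compound 1 to compound 2 (within the scatter) shows to lie within the scatter of each other, so compound 1 stands nowhere apart from compound 2. Compound 3 `CCC(CC)OC(=O)C1=C(C)NC(=O)NC1c1ccoc1` differs from compound 1 by (pentan-3-yl)oxy in place of amino on a carbonyl carbon. Going by the values given here, no measured step touches this carbonyl carbon; the only measured step concerns the group on a saturated ring carbon and says nothing about this change. With both measured numbers low, no step beyond the scatter is expected, and the estimated step is no change at the digits printed from compound 1 to compound 3 (within the scatter). Compound 3 is expected to give 6%, with a range from -5% to 25%.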

Compound 3, a percentage reported as inhibition, at one concentration (the size of the read-out at that concentration, not a potency): 28%
Compound 3: middle estimate off by 22 percentage points, on the low side, outside the stated range (above it).
By their numbers in this assay, from the lowest: compounds 2 and 1 (each within the scatter of the next); then compound 3.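

Going by these compounds alone, the carbonyl carbon is the first position where a change moves the number in this assay beyond the scatter: (pentan-3-yl)oxy in place of amino gives a number 22 percentage points higher from compound 1 to compound 3 (beyond the scatter), a modest step. Within the data shown here, the one earlier step, on the saturated ring carbon, gave no such separation. Nothing measured explains the step. Open, from the compounds shown here alone, is whether the oxygen link or the pentan-3-yl chain carries it; methoxy, a longer chain or a carboxylic acid at this carbonyl carbon would separate these. Also open, going by these compounds, is whether thiophen-3-yl behaves alike with (pentan-3-yl)oxy in place.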